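A few compounds are considered here, and "the series" means these few. Any claim that something is new, unique, unknown or untested is made for them only; others in the source may bear on it.

Compound 1 `CC(=O)N1CCN(c2cccc(-c3cc(C#N)c4c(N)ncnn34)c2)C(=O)C1(C)C`: 84 nm/s
Compound 2 `COc1ccc(-c2cc(Cl)c3c(N)ncnn23)cc1N1CCN(C(C)=O)C(C)(C)C1=O`: 170 nm/s

The measurements come from an ADME assay on Caco-2 cells (Homo sapiens) for permeability, in the apical to basolateral direction; a higher number here means that the compound crosses the layer faster, a lower number that the compound crosses the layer more slowly. Compound 2 gives 170 nm/s, the higher of the two numbers. Compound 1 gives 84 nm/s, and that gap lies just beyond the scatter.

The next molecule, compound 3 `CC(=O)N1CCN(c2cc(-c3cc(Cl)c4c(N)ncnn34)ccc2C#N)C(=O)C1(C)C`, keeps the rest of compound 2 but has cyano in place of methoxy on an aromatic carbon, ortho to a large group and para to a large group (cyano in place of methoxy on an aromatic carbon). Going by the values given here, no pair of measured compounds shows this change on its own, so the guide is thin. Compound 1 also carries a cyano group, though it differs from compound 2 in more than one place, and two compounds establish no pattern. Even so, the lower number of compound 1 at 84 nm/s tilts the expectation downward. The expected change is a 1.8-fold lower number from compound 2 to compound 3 (0.25 log units; within the scatter), a modest fall close to the edge of the scatter. For compound 3 the estimated value is 95 nm/s, with an expected range from 45 nm/s to 200 nm/s.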

Compound 3, apparent permeability: 200 nm/s
Estimate against measurement, compound 3: 2.1-fold (0.32 log units) below, within the range that was stated.
By their numbers in this assay, from the lowest: compound 1; then compounds 2 and 3 (each within the scatter of the next).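

In this assay the swap of methoxy for cyano on an aromatic carbon, ortho to a large group and para to a large group, gives a 1.2-fold higher number from compound 2 to compound 3 (0.07 log units; within the scatter) and so stays within the scatter. Going by these compounds alone, this is the first pair here that differs in one place only, and it shows that this read-out does not separate the two groups at this position, at least with the rest of compound 2 held fixed. No measurement at hand explains this result.

One pair says nothing about larger or differently built groups on the same carbon, so an amine, a carboxylic acid or a longer chain such as ethoxy could behave quite differently there. From the compounds shown here alone, compound 1 differs from compound 2 and compound 3 in more than one place, so its place cannot be traced to any single part of the structure, and whether the swap would give the same result on the core of compound 1 remains open.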